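A Thioether in Place of a Pentyl Chain

The compounds below may be only part of what the source reports. "The series", "measured", "known", "first", "only" and "open" are said of these compounds alone.

Of the compounds shown here, two have so far been measured in a functional assay for inhibition of sodium/hydrogen exchanger (Oryctolagus cuniculus); a higher number here means a weaker inhibitor, a lower number a stronger inhibitor. Compound 1 `CCCCCc1cc(C)c(C(=O)N=C(N)N)cc1S(C)(=O)=O` gives 27 nM, the lowest of the two numbers. Compound 2 `Cc1ccc(-c2ccc(C(=O)N=C(N)N)cc2S(C)(=O)=O)cc1` gives 100 nM in this assay, a higher number than that of compound 1 by a gap beyond the usual scatter; the two structures differ in more than one place, so this gap is not tied to any single change.

Compound 3 `CCCSc1cc(C)c(C(=O)N=C(N)N)cc1S(C)(=O)=O` has not yet been measured. It differs from compound 1 in one place: propylsulfanyl in place of pentyl on an aromatic carbon. Among the compounds with values here, no measured pair isolates this change, so nothing in the data fixes its size or direction. The step of a 1.3-fold higher number from compound 1 to compound 3 (0.11 log units; within the scatter) is expected to be small, within or close to the scatter, with no clear direction. Compound 3 is therefore estimated at 35 nM in this assay, with a range from 12 nM to 100 nM.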

Compound 3, half-maximal inhibitory concentration: 6.8 nM
Estimate against measurement, compound 3: 5.1-fold (0.71 log units) above; the measured number lies below the stated range.
By their numbers in this assay, from the lowest: compound 3; then compound 1; then compound 2.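

In this assay, propylsulfanyl in place of pentyl on the aromatic carbon ortho to the methylsulfonyl group gives a 4.0-fold lower number from compound 1 to compound 3 (0.60 log units; beyond the scatter), which shows that this position is sensitive to the change and that the pentyl chain is not needed for a low number. The swap changes several things at once: the entering group has one heavy atom fewer, brings in a sulfur atom and counts one hydrogen-bond acceptor where pentyl counts none. Nothing available here explains the drop in the number.

The compounds shown leave open whether the sulfur atom or the shorter chain accounts for the step, as the two enter together. A propoxy or a butyl group on the same carbon would separate them, and a pentylsulfanyl group would test the chain length with the sulfur kept.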